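Trimming the Side Chain of an Oral Compound

This account rests on a few compounds, and the source may have more. Where it says the series, first, only, none or still open, it means among the compounds named here.

Compound 1 `N=C(N)NCCC[C@H](NC(=O)CN(c1nc(Cl)nc2[nH]cnc12)C1CC1)C(=O)O`: 51%
Compound 2 `N=C(N)NCCC[C@H](NC(=O)CN(c1nc(Cl)nc2[nH]cnc12)C1CC1)C(=O)OCc1ccccc1`: 30.6%
Compound 3 `NC(=O)C[C@H](NC(=O)CN(c1ncnc2c1ncn2C1CCCCO1)C1CC1)C(=O)OCc1ccccc1`: 30.5%

In a functional assay on the whole organism (Tail, strain ICR) with Mus musculus as the target, in the tail flick test, with a stated time of 60 min, at a dose of 25 umol/kg by the oral route (on this read-out higher numbers stand for a stronger effect at the one dose given and lower numbers for a weaker effect), compound 1 gives 51%, the highest of the three numbers, standing beyond the scatter from both compound 2 and compound 3. Within the data shown here, the only single-change step measured so far is a number 20.4 percentage points lower from compound 1 to compound 2 (beyond the scatter), a change at the acid end of the molecule.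

Compound 4 `C[C@H](NC(=O)CN(c1nc(Cl)nc2[nH]cnc12)C1CC1)C(=O)O` differs from compound 1 by a hydrogen atom in place of a group of 6 heavy atoms (3 carbon, 3 nitrogen; no ring), on a saturated chain carbon, two bonds along the chain from an amide-type nitrogen and a carbonyl carbon. Among the measured compounds shown here, no measured step touches this part of the molecule, so the ester step offers a sense of scale but no direction. Removing so much of the structure is treated here as a likely loss. Compound 4 is therefore estimated at 30%, with a range from 10% to 55%, which means an expected step of a number 21 percentage points lower from compound 1 to compound 4 (beyond the scatter).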

Compound 4, a percentage reported as activity, at one dose (the size of the read-out at that dose, not a potency): 44.6%
Compound 4: middle estimate off by 14.6 percentage points, on the low side, and the stated range covers the measured number.
By their numbers in this assay, from the lowest: compounds 3 and 2 (each within the scatter of the next); then compounds 4 and 1 (each within the scatter of the next).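

In this assay, a hydrogen atom in place of the group of 6 heavy atoms (3 carbon, 3 nitrogen; no ring) gives a number 6.4 percentage points lower from compound 1 to compound 4 (within the scatter). At this one oral dose, then, the effect does not need that whole group on the saturated chain carbon, something the earlier change at the acid end could not show. No measurement here explains this result.

The compounds shown leave open how a short chain ending in an amine would read at this carbon. They also leave open whether a benzyl ester on compound 4 would read as it does on compound 2.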